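Working notes: amide substituent variation in a sirtuin-6 series

The source may hold more compounds than are shown below. What is called first, only, known or untested is meant among the compounds shown, and "the series" means these compounds.

Measured so far:
compound 1, `CCCCCCCCNC(=O)CCCSC[C@H](NC(=O)OCc1ccccc1)C(=O)Nc1ccccc1` — "not active" (no number reported)
compound 2, `CCCCNC(=O)CCCSC[C@H](NC(=O)OCc1ccccc1)C(=O)Nc1ccccc1` — 26%
compound 3, `CCCCCCCCCCCCCNC(=O)CCCSC[C@H](NC(=O)OCc1ccccc1)C(=O)Nc1ccccc1` — 31%

In an assay for inhibition of NAD-dependent protein deacylase sirtuin-6 (Homo sapiens), read by HPLC, with stated times of 15 min and 1 h, tested at 333 uM (on this read-out lower numbers stand for less inhibition and higher numbers for more inhibition at the one concentration tested (going by the name of the read-out)), compound 1 gave no number and was reported as "not active" (no number reported). Compound 2 gives 26% and compound 3 gives 31%. Compound 3 therefore holds the highest of the two numbers shown, but the step of a number 5 percentage points higher from compound 2 to compound 3 (within the scatter) lies within the scatter, so compound 2 and compound 3 cannot be ordered, and compound 1 contributes no number at all.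

Compound 4, `O=C(O)CNC(=O)CCCSC[C@H](NC(=O)OCc1ccccc1)C(=O)Nc1ccccc1`, differs from compound 3 as follows: carboxy in place of dodecyl on a saturated chain carbon bound to an amide-type nitrogen. Going by the values given here, the only step bearing on the end of this chain is a number 5 percentage points higher from compound 2 to compound 3 (within the scatter), which was within the scatter, and it concerns a longer chain rather than a carboxy group; no measured step covers carboxy at this place. The expected change a number 11 percentage points lower from compound 3 to compound 4 (beyond the scatter) is therefore small and uncertain, with direction not supported by the measured steps. For compound 4 an inhibition of about 20% is expected, estimated to fall between 0% and 40%, with a real chance that only a report of no activity is returned.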

Compound 4, a percentage reported as inhibition, at one concentration (the size of the read-out at that concentration, not a potency): 53%
Beside the measured number, compound 4's estimate is 33 percentage points below it; measured number outside the range, above it.
By their numbers in this assay, from the lowest: compounds 2 and 3 (each within the scatter of the next); then compound 4.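

In this assay the end of this substituent now gives steps beyond the scatter: with carboxy in place of dodecyl on a saturated chain carbon bound to an amide-type nitrogen the result is a number 22 percentage points higher from compound 3 to compound 4 (beyond the scatter), and with carboxy in place of propyl at that place it is a number 27 percentage points higher from compound 2 to compound 4 (beyond the scatter). Going by these compounds alone, the earlier change among the chains alone, a number 5 percentage points higher from compound 2 to compound 3 (within the scatter), stayed within the scatter, so the exchange for carboxy is the first change at this place that can be read, while compound 1 offers no number for comparison. No measurement available here explains the rise.

From the compounds shown here alone, whether the carboxylic acid itself is needed remains open, and a methyl ester or an amine at the same place would test that. Also open, going by these compounds, is whether a longer chain between the amide nitrogen and the carboxy group keeps the gain.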